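Cytotoxicity notes: bulkier amine substituents on the shared core

This account rests on a few compounds, and the source may have more. Where it says the series, first, only, none or still open, it means among the compounds named here.

Compound 1 `CNc1nc(C)c(-c2nc3cnccc3s2)c(N[C@@H]2C[C@H](CO)[C@@H](O)[C@H]2O)n1` gives 14000 nM in an ADME assay on cells (Homo sapiens) for cytotoxicity, read by polymerase chain reaction, with a stated time of 3 days (on this read-out higher numbers stand for lower toxicity in this test and lower numbers for higher toxicity in this test), the lowest of the three numbers, though its steps to both other compounds fall within the scatter. Compound 2 `Cc1nc(N(C)C)nc(N[C@@H]2C[C@H](CO)[C@@H](O)[C@H]2O)c1-c1nc2cnccc2s1` gives 25000 nM in this assay and compound 3 `Cc1nc(NC(C)(C)c2ccccc2)nc(N[C@@H]2C[C@H](CO)[C@@H](O)[C@H]2O)c1-c1nc2cnccc2s1` gives 25000 nM. The steps of a 1.8-fold higher number from compound 1 to compound 2 (0.25 log units; within the scatter) and a 1.8-fold higher number from compound 1 to compound 3 (0.25 log units; within the scatter) both alter the same nitrogen; no change at the digits printed from compound 2 to compound 3 (within the scatter) shows the large 1-methyl-1-phenylethyl group reading like dimethylamino. Compound 4 `Cc1ccc(C2(Nc3nc(C)c(-c4nc5cnccc5s4)c(N[C@@H]4C[C@H](CO)[C@@H](O)[C@H]4O)n3)CC2)cc1` carries the change (1-(4-methylphenyl)cyclopropyl in place of methyl on a nitrogen on an aromatic ring). Going by the values given here, the closest precedent is the step from compound 1 to compound 3, also a large group on this nitrogen, so no step beyond the scatter is expected, with a slight upward lean: a 1.4-fold higher number from compound 1 to compound 4 (0.15 log units; within the scatter). Compound 4 is thus estimated at 20000 nM, range 8000 nM to 50000 nM.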

Compound 4, half-maximal cytotoxic concentration: 25000 nM
The estimate for compound 4 lay 1.3-fold (0.10 log units) below the measured number; the measured number falls inside the stated range.
By their numbers in this assay, from the lowest: compounds 1, 2, 3 and 4 (each within the scatter of the next).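

On the nitrogen on an aromatic ring, 1-(4-methylphenyl)cyclopropyl in this assay gives a 1.8-fold higher number from compound 1 to compound 4 (0.25 log units; within the scatter), so a second large group, this one with a three-membered ring, also stays within the scatter of methyl. Against the other large group the result is no change at the digits printed from compound 3 to compound 4 (within the scatter), and against dimethylamino it is no change at the digits printed from compound 2 to compound 4 (within the scatter), so none of the four substituents on this nitrogen separates from the others. No measurement at hand accounts for these numbers. From the compounds shown here alone, whether a carboxylic acid or a longer chain ending in an amine on this nitrogen would step beyond the scatter remains open.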